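The source may report more compounds than this note shows. Statements on the series, on what has been measured and on what is new or still open speak of the compounds shown alone.

Working notes on the series of trimethoxybenzoyl pyrroles tested in a functional assay on MCF7 cells (Homo sapiens) for cytotoxicity, read by MTT assay, with a stated time of 96 h; on this read-out higher numbers stand for weaker inhibition and lower numbers for stronger inhibition.

Three compounds have numbers. Compound 1, `COc1cc(C(=O)c2cn(-c3ccccc3N)cc2-c2ccccc2)cc(OC)c1OC`, gives 3800 nM. Compound 2, `COc1ccc(-n2cc(C(=O)c3cc(OC)c(OC)c(OC)c3)c(-c3ccccc3)c2)cc1`, gives 120 nM. Compound 3, `COc1cc(C(=O)c2cn(-c3ccccc3)cc2-c2ccccc2C)cc(OC)c1OC`, gives 190 nM. Compound 3 thus stands second highest of the three; its nearest neighbour is compound 2, a gap within the scatter, and its furthest is compound 1, a gap beyond the scatter. Among the measured compounds shown here, the one single-point step measured so far is a 32-fold lower number from compound 1 to compound 2 (1.50 log units; beyond the scatter), and it concerns the group on the aromatic nitrogen only.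

Compound 4, `COc1cc(C(=O)c2cn(-c3ccccc3)cc2/C=C/c2ccccc2)cc(OC)c1OC`, is the next in line. Its difference from compound 3 is 2-phenylethenyl in place of 2-methylphenyl on an aromatic carbon. For the measured compounds named here, no measured step touches the group on that aromatic carbon, so the step from compound 1 to compound 2 gives no direct guide here; it shows only that the series can swing widely with a single change. With the phenyl kept and a double bond outside aromatic rings now linking it to the shared core, a moderate shift is expected rather than a large one, and the direction is uncertain. The step of a 2.1-fold higher number from compound 3 to compound 4 (0.32 log units; beyond the scatter) is the expected outcome. For compound 4 the estimate is 400 nM, with a range from 100 nM to 1600 nM.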

Compound 4, half-maximal inhibitory concentration: 2200 nM
Compound 4: the middle estimate sits 5.5-fold (0.74 log units) below what was measured, outside the stated range (above it).
By their numbers in this assay, from the lowest: compounds 2 and 3 (each within the scatter of the next); then compounds 4 and 1 (each within the scatter of the next).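

In this assay, the change on the aromatic carbon next to the ring atom that bears a large group gives a 12-fold higher number from compound 3 to compound 4 (1.06 log units; beyond the scatter), the first step read at this position. It shows that this place, like the aromatic nitrogen with its step of a 32-fold lower number from compound 1 to compound 2 (1.50 log units; beyond the scatter), can move the number far beyond the scatter with a single change. The large rise in the number, which stands for weaker inhibition, comes even though 2-phenylethenyl keeps the six-membered aromatic ring of 2-methylphenyl and the hydrogen-bond donor and acceptor counts stay the same, so those shared features do not protect the value; no measurement available here bears on what lies behind the rise.

The compounds shown leave open whether the rise goes with the double bond outside aromatic rings or with the ring being carried on a linker at all, a question that a 2-phenylethyl group or a plain phenyl at this position would address. They also leave open how groups with nitrogen or oxygen, such as an amine or a carboxylic acid, would fare at this aromatic carbon.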